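Acetyl for methyl on the ring nitrogen of compound 3

The source may hold more compounds than are shown below. What is called first, only, known or untested is meant among the compounds shown, and "the series" means these compounds.

Of the compounds shown here, three sharing one core have been measured in an ADME assay on cells (Hepatocyte, Rattus norvegicus) for metabolic stability; a higher number here means faster removal of the compound, a lower number slower removal. Compound 1 `O=C(N[C@H]1CN(S(=O)(=O)c2ccccc2)C[C@@H]1C(=O)N[C@H]1CCCNC1)c1cc(-c2ccccc2Cl)on1` gives 8.3 uL/min. Compound 2 `O=C(N[C@H]1CN(S(=O)(=O)c2ccccc2)C[C@@H]1C(=O)N1C[C@H]2CCNC[C@H]21)c1cc(-c2ccccc2Cl)on1` gives 4.7 uL/min, a change of a 1.8-fold lower number from compound 1 to compound 2 (0.25 log units; within the scatter). Compound 3 `CN1CCC[C@H](NC(=O)[C@H]2CN(S(=O)(=O)c3ccccc3)C[C@@H]2NC(=O)c2cc(-c3ccccc3Cl)on2)C1` gives 31 uL/min, the highest of the three: it sits a 3.7-fold higher number from compound 1 to compound 3 (0.57 log units; beyond the scatter) and a 6.6-fold higher number from compound 2 to compound 3 (0.82 log units; beyond the scatter).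

The next compound, compound 4 `CC(=O)N1CCC[C@H](NC(=O)[C@H]2CN(S(=O)(=O)c3ccccc3)C[C@@H]2NC(=O)c2cc(-c3ccccc3Cl)on2)C1`, differs from compound 3 in one place: acetyl in place of methyl on an amine nitrogen in a ring. Among the measured compounds shown here, no measured pair shows this exact exchange, so the nearest guide is the step at the same ring nitrogen, where a methyl replaced a hydrogen and the number rose beyond the scatter. That step shows the substituent on this nitrogen can shift the read-out by a modest amount. Because a 3.7-fold higher number from compound 1 to compound 3 (0.57 log units; beyond the scatter) reflects what the methyl itself added, removing it in favour of an acetyl is expected to pull the number back toward compound 1, giving a step of about a 2.1-fold lower number from compound 3 to compound 4 (0.32 log units; beyond the scatter). Compound 4 is therefore estimated at 15 uL/min, within a range from 5 uL/min to 45 uL/min.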

Compound 4, intrinsic clearance in a liver preparation (reported as CLH), per the amount of preparation that the assay uses in the Hepatocyte assay: 196 uL/min
Compound 4: the middle estimate sits 13-fold (1.12 log units) below what was measured; the measured number lies above the stated range.
By their numbers in the Hepatocyte assay, from the lowest: compounds 2 and 1 (each within the scatter of the next); then compound 3; then compound 4.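

On this ring nitrogen, the substituent sets the rate of removal in the Hepatocyte assay: going from hydrogen to methyl to acetyl, the number rises at each step, and acetyl gives a 6.3-fold higher number from compound 3 to compound 4 (0.80 log units; beyond the scatter), a 24-fold higher number from compound 1 to compound 4 (1.37 log units; beyond the scatter) and a 42-fold higher number from compound 2 to compound 4 (1.62 log units; beyond the scatter), which leaves compound 4 with the fastest removal of the four. The same exchange also bears on a second property, where in a physicochemical assay for solubility, at pH 7.4 (a lower number here means a less soluble compound, a higher number a more soluble compound), compound 3 gives 503000 nM. In the physicochemical assay compound 4 gives < 500 nM, which is a limit of the assay and not a number.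

The compounds shown leave open whether the rise in removal belongs to acetyl alone or extends to other groups on this nitrogen. A propionyl or a methylsulfonyl group there, or a longer alkyl chain, would help to separate these possibilities.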